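A few compounds are considered here, and "the series" means these few. Any claim that something is new, unique, unknown or untested is made for them only; others in the source may bear on it.

Working notes on the series. For the measured compounds named here, in a functional assay on CHO-K1 cells for agonist activity at Glucose-dependent insulinotropic receptor (Homo sapiens), read by HTRF and cAMP accumulation, with a stated time of 30 min (a higher number here means that more compound is needed for the effect, a lower number that less compound is needed), three compounds have numbers so far. Compound 1, `CC(C)(C)OC(=O)N1CCC(CCCOc2ccc3c(c2)CCS3(=O)=O)CC1`, gives 736 nM. Compound 2, `CC(C)(C)OC(=O)N1CCC(CCCNc2ccc3c(c2)OCS3(=O)=O)CC1`, gives 254 nM. Compound 3, `CCc1cnc(N2CCC(CCCNc3ccc4c(c3)OCC4=O)CC2)nc1`, gives 117 nM, the lowest of the three numbers; its nearest neighbour is compound 2, whose number stands higher by a margin beyond the scatter, and compound 1 stands furthest from it, also beyond the scatter. No two of the measured compounds differ in a single place, so no isolated step can be read off from them.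

The next compound, compound 4, is `CC(C)c1nnc(N2CCC(CCCNc3ccc4c(c3)OCC4=O)CC2)o1`. It differs from compound 3 only by 5-isopropyl-1,3,4-oxadiazol-2-yl in place of 5-ethylpyrimidin-2-yl on an amine nitrogen in a ring. Going by the values given here, nothing among the measured compounds shows what this particular exchange does in this assay; the swap keeps the group on the amine nitrogen at the same heavy-atom count and adds one hydrogen-bond acceptor. Among the compounds with values here, with no measured precedent, the expected step from compound 3 to compound 4 is small, a 1.3-fold higher number from compound 3 to compound 4 (0.11 log units; within the scatter), most likely within the scatter and with no firm direction. For compound 4 the estimated value in this assay is 150 nM, with a range from 50 nM to 450 nM.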

Compound 4, half-maximal effective concentration: 704 nM
Estimate against measurement, compound 4: 4.7-fold (0.67 log units) below; measured number above the stated range.
By their numbers in this assay, from the lowest: compound 3; then compound 2; then compounds 4 and 1 (each within the scatter of the next).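

In this assay, the group on an amine nitrogen in a ring is not interchangeable: a 6.0-fold higher number from compound 3 to compound 4 (0.78 log units; beyond the scatter), a modest step beyond the scatter, even though 5-ethylpyrimidin-2-yl and 5-isopropyl-1,3,4-oxadiazol-2-yl have the same heavy-atom count and neither carries a net charge. For the compounds shown here, this is the first single-place comparison, and it shows that, on this core, matching the size of the group by heavy-atom count does not preserve the number when the six-membered aromatic ring gives way to the five-membered one with its additional hydrogen-bond acceptor. Nothing measured here accounts for the step.

The exchange alters the ring and the alkyl group together, so the compounds shown do not separate the two; a 5-isopropylpyrimidin-2-yl or a 5-ethyl-1,3,4-oxadiazol-2-yl group at the same nitrogen would be needed to assign the step to one part or the other. Also open, as far as these compounds go, is whether either ring, placed instead of the tert-butoxycarbonyl group on the cores of compound 1 and compound 2, would give a step of similar size and direction.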